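Phenyl in Place of Propyl on a Dienamide Chain

A few compounds are considered here, and "the series" means these few. Any claim that something is new, unique, unknown or untested is made for them only; others in the source may bear on it.

Compound 1, `CCC/C(=C\C=C\C(=O)N[C@H](C)CCCc1cccnc1)c1ccc(OC)cc1`: 0.52 mg/kg
Compound 2, `O=C(/C=C/C=C(c1ccc(Cl)cc1)c1ccc(Cl)cc1)NCCCCc1cccnc1`: 0.18 mg/kg

Both measured compounds were tested in a functional assay with platelet-activating factor receptor (Cavia porcellus) as the target; on this read-out lower numbers stand for an effect already at smaller amounts and higher numbers for an effect only at larger amounts of compound. Of the two numbers, compound 1 stands at the higher one; compound 2 gives a lower number, and the gap between them lies beyond the usual scatter of repeated measurements. Going by the values given here, no pair of measured compounds differs in only one place, so there is no single-change step to lean on, and any expectation for a new compound rests on these two values and the structural change itself.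

Compound 3, `COc1ccc(/C(=C/C=C/C(=O)N[C@H](C)CCCc2cccnc2)c2ccccc2)cc1`, is the untested compound of interest. It differs from compound 1 in one place: phenyl in place of propyl on a double-bonded chain carbon bound to an aromatic carbon and a double-bonded chain carbon. The change keeps the amide, the pyridine-bearing chain and the methoxy-substituted ring of compound 1 unchanged and only exchanges the group on that chain carbon.

Among the compounds with values here, with no directly comparable step on hand, the expected step from compound 1 to compound 3 a 1.7-fold lower number from compound 1 to compound 3 (0.24 log units; within the scatter) is a modest move toward a lower number, estimated to fall within or just beyond the scatter. Compound 3 is therefore estimated to give 0.3 mg/kg, with a range from 0.1 mg/kg to 0.9 mg/kg.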

Compound 3, dose for 50% inhibition: 0.16 mg/kg
Beside the measured number, compound 3's estimate is 1.9-fold (0.27 log units) above it; measured number inside the range.
By their numbers in this assay, from the lowest: compounds 3 and 2 (each within the scatter of the next); then compound 1.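

In this assay, going by these compounds alone, the exchange of propyl for phenyl on a double-bonded chain carbon bound to an aromatic carbon and a double-bonded chain carbon gives a 3.3-fold lower number from compound 1 to compound 3 (0.51 log units; beyond the scatter) and provides the first single-change step in this set, showing that the number responds to what sits at this position. Neither group carries a hydrogen-bond donor, a hydrogen-bond acceptor or a net charge, so this step needed none of these on the entering group; what differs is that a chain of 3 heavy atoms gives way to a six-membered aromatic ring of 6 heavy atoms. Nothing measured here explains why the number moves with this exchange.

A single step cannot separate the effect of having a ring at this position from the effect of having more heavy atoms there, and a cyclohexyl ring, which has the same number of carbons but is not aromatic, or a longer chain such as hexyl would be needed to tell the two apart. Going by these compounds, how a group such as an amine or a carboxylic acid at this position would shift the number also remains open.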